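This account rests on a few compounds, and the source may have more. Where it says the series, first, only, none or still open, it means among the compounds named here.

Among the compounds with values here, compound 3 `NC(=O)c1c(NC(=O)c2ccccc2Cl)sc2c1CCN(C(=S)Nc1ccccc1F)C2` gives 12600 nM in a functional assay on MKN-74 cells (Homo sapiens) for antiproliferative activity, with a stated time of 24 h (a lower number here means a stronger inhibitor, a higher number a weaker inhibitor), the second highest of the three numbers so far. Compound 1 `NC(=O)c1c(NC(=O)c2ccccc2Cl)sc2c1CCN(Cc1ccc([N+](=O)[O-])cc1)C2` gives 31500 nM, and compound 2 `NC(=O)c1c(NC(=O)c2ccccc2Cl)sc2c1CCN(Cc1c(Cl)cccc1Cl)C2` gives 4740 nM. The step of a 2.5-fold lower number from compound 1 to compound 3 (0.40 log units; beyond the scatter) and the step of a 2.7-fold higher number from compound 2 to compound 3 (0.42 log units; beyond the scatter) place compound 3 between the other two. Compound 4 `NC(=O)c1c(NC(=O)c2ccccc2Cl)sc2c1CCN(C(=S)Nc1ccc(C(F)(F)F)cc1)C2` differs from compound 3 by 4-(trifluoromethyl)phenyl in place of 2-fluorophenyl on an amide-type nitrogen. Within the data shown here, no measured step alters this part of the molecule; the steps that exchange the group on the ring nitrogen, a 6.6-fold lower number from compound 1 to compound 2 (0.82 log units; beyond the scatter) and a 2.7-fold higher number from compound 2 to compound 3 (0.42 log units; beyond the scatter), were modest, so only a modest step is expected here, with no clear direction. Compound 4 is expected to give 10000 nM in this assay, with a range from 3000 nM to 35000 nM. That estimate means a step of a 1.3-fold lower number from compound 3 to compound 4 (0.10 log units; within the scatter).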

Compound 4, half-maximal inhibitory concentration: 7090 nM
For compound 4 the middle estimate is 1.4-fold (0.15 log units) above the measured one, and the stated range covers the measured number.
By their numbers in this assay, from the lowest: compounds 2, 4 and 3 (each within the scatter of the next, the first and the last beyond it); then compound 1.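

Within the data shown here, this is the first change on the amide-type nitrogen itself. In this assay, 4-(trifluoromethyl)phenyl in place of 2-fluorophenyl gives a 1.8-fold lower number from compound 3 to compound 4 (0.25 log units; within the scatter) on the otherwise unchanged molecule, so this exchange does not separate the two compounds, even though both the substituent and its printed ring position differ. Nothing measured here offers an explanation for this result. The compounds shown leave open how plain phenyl or 4-fluorophenyl would compare, which would test one difference at a time. They also leave open whether a non-aromatic group, such as a short alkyl chain, could replace the ring.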